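From 4-hydroxyphenyl to 2,4-dichlorophenyl: notes on compound 3

The source may hold more compounds than are shown below. What is called first, only, known or untested is meant among the compounds shown, and "the series" means these compounds.

Two members of the series have been measured so far, compound 1 (`COc1ccc(/C=C2\CCC/C(=C\c3ccc(Br)cc3)C2=O)cc1OC`) and compound 2 (`COc1ccc(/C=C2\CCC/C(=C\c3ccc(O)cc3)C2=O)cc1OC`). In a functional assay on MCF7 cells (Homo sapiens) for cytotoxicity, read by MTT assay, with a stated time of 72 h (on this read-out higher numbers stand for weaker inhibition and lower numbers for stronger inhibition), compound 1 gives 6900 nM and compound 2 gives 17000 nM. Compound 2 therefore has the higher of the two numbers, and its gap to compound 1 lies beyond the scatter.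

Compound 3 (`COc1ccc(/C=C2\CCC/C(=C\c3ccc(Cl)cc3Cl)C2=O)cc1OC`) is the next to be measured. The change is 2,4-dichlorophenyl in place of 4-hydroxyphenyl on a double-bonded chain carbon bound to a double-bonded ring carbon, on a double-bonded chain carbon bound to a double-bonded ring carbon.

For the measured compounds named here, one measured step bears on this: a 2.5-fold higher number from compound 1 to compound 2 (0.39 log units; beyond the scatter). This modest step is hydroxy in place of bromo on an aromatic carbon. Compound 3 also lacks the hydroxy, but it carries two chlorines rather than a bromo, so the step is only an indirect guide when read in reverse. A modest step toward a lower number is therefore expected in this assay.

The expected step is a 2.4-fold lower number from compound 2 to compound 3 (0.39 log units; beyond the scatter). The estimate for compound 3 is 7000 nM, with an expected range from 2500 nM to 18000 nM.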

Compound 3, half-maximal inhibitory concentration: 16200 nM
Compound 3: the middle estimate sits 2.3-fold (0.36 log units) below what was measured; the range from low to high includes it.
By their numbers in this assay, from the lowest: compound 1; then compounds 3 and 2 (each within the scatter of the next).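

The exchange of 4-hydroxyphenyl for 2,4-dichlorophenyl on a double-bonded chain carbon bound to a double-bonded ring carbon gives a 1.0-fold lower number from compound 2 to compound 3 (0.02 log units; within the scatter) in this assay and so leaves compounds 2 and 3 level, even though the hydrogen-bond donor and acceptor of the 4-hydroxyphenyl group are gone. Replacing the hydroxy-bearing ring with a halogen-bearing one therefore does not by itself reproduce the lower number of compound 1, and the comparison with the 4-bromophenyl group shows a 2.3-fold higher number from compound 1 to compound 3 (0.37 log units; beyond the scatter) at the same position. Among these three compounds, the lower number belongs to the 4-bromophenyl group alone, not to halogen substitution in general or to the absence of the hydroxy, and no supporting measurement is available to explain this difference.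

The compounds shown leave open whether 4-chlorophenyl would read with compound 1 or with compound 3, a comparison that would separate the identity of the halogen from the presence of a second chlorine. From the compounds shown here alone, how a 4-aminophenyl or 4-carboxyphenyl group would read at this position also remains open.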